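The source may hold more compounds than are shown below. What is called first, only, known or untested is meant among the compounds shown, and "the series" means these compounds.

Measured compounds so far:
compound 1 `CC(C)[C@H](NC(=O)COc1cccc2ccccc12)C(=O)N[C@@H](CC(=O)O)C(=O)COc1ccccc1[N+](=O)[O-]` – in a functional assay on Jurkat cells (Homo sapiens) (on this read-out higher numbers stand for weaker inhibition and lower numbers for stronger inhibition), compound 1 gives > 100000 nM, which is a limit of the assay and not a number.
compound 2 `CC(C)[C@H](NC(=O)COc1cccc2ccccc12)C(=O)N[C@@H](CC(=O)O)C(=O)COc1c(F)c(F)cc(F)c1F` – in this assay compound 2 gives 4500 nM.

Compound 1 therefore stands only at the limit of > 100000 nM in this assay, at which 1 of the 2 values shown sits; no number is known for it. For the measured compounds named here, the one measured step, an at least 22-fold lower number from compound 1 to compound 2 (1.34 log units; beyond the scatter), shows that replacing the 2-nitrophenyl on the oxygen on the saturated carbon can bring the number down from the limit by a large margin.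

Compound 3 `CC(C)[C@H](NC(=O)COc1cccc2ccccc12)C(=O)N[C@@H](CC(=O)O)C(=O)COc1ccc([N+](=O)[O-])cc1F` has not yet been measured. It differs from compound 1 as follows: 2-fluoro-4-nitrophenyl in place of 2-nitrophenyl on an oxygen on a saturated carbon. Going by the values given here, the only step that bears on it is an at least 22-fold lower number from compound 1 to compound 2 (1.34 log units; beyond the scatter); that change is not the same as the one in compound 3, so a smaller move is expected. Compound 3 is estimated at 20000 nM, range 4000 nM to 100000 nM, in the same direction, an expected step of an at least 5.0-fold lower number from compound 1 to compound 3 (0.69 log units; beyond the scatter).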

Compound 3, half-maximal inhibitory concentration: 30300 nM
For compound 3 the middle estimate is 1.5-fold (0.18 log units) below the measured one; measured number inside the range.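

In this assay, a nitro-bearing ring on the oxygen on the saturated carbon does not by itself hold the number at the limit: 2-fluoro-4-nitrophenyl in place of 2-nitrophenyl gives an at least 3.3-fold lower number from compound 1 to compound 3 (0.51 log units; beyond the scatter). The same group in place of 2,3,5,6-tetrafluorophenyl gives a 6.7-fold higher number from compound 2 to compound 3 (0.83 log units; beyond the scatter), so compound 2 keeps the lowest number of the three and this position separates all three aryl groups. Compound 1 remains a limit and not a number, so the first step has only a lower bound: the limit of > 100000 nM in this assay, at which 1 of the 3 values shown sits.

Whether the added fluorine or the changed place of the nitro group carries the first step stays open, as the compounds shown do not separate the two. Also open, as far as these compounds go, is how an unsubstituted phenyl, or a phenyl bearing an amine or a carboxylic acid, would read here.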